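Cyano for Chloro on the Fused Ring of Compound 2

A few compounds are considered here, and "the series" means these few. Any claim that something is new, unique, unknown or untested is made for them only; others in the source may bear on it.

Compound 2 `O=S(=O)(c1ccc(F)cc1)c1cnc2cc(Cl)ccc2c1-c1ccc(Cl)cc1` gives 0.21 mL/min in an ADME assay on microsomes from liver (Homo sapiens) for metabolic stability, tested at 2.5 uM (on this read-out lower numbers stand for slow clearance and higher numbers for fast clearance), the lowest of the two numbers recorded so far. For the measured compounds named here, its nearest neighbour, compound 1 `O=S(=O)(c1ccc(F)cc1)c1cnc2cc(F)ccc2c1-c1ccc(Cl)cc1`, gives 1.23 mL/min in this assay, and the single measured step, a 5.9-fold lower number from compound 1 to compound 2 (0.77 log units; beyond the scatter), shows how far one change at this position of the shared core has moved the read-out. Compound 3 `N#Cc1ccc2c(-c3ccc(Cl)cc3)c(S(=O)(=O)c3ccc(F)cc3)cnc2c1` differs from compound 2 by cyano in place of chloro on an aromatic carbon. Going by the values given here, no measured step concerns a cyano group, and the only step available involves two halogens, so it bears on this change only by showing that substitution at this place on the core can shift the read-out well beyond the scatter in either direction. The account therefore expects for compound 3 a step of a 1.9-fold higher number from compound 2 to compound 3 (0.28 log units; within the scatter), an upward movement of uncertain size. Compound 3 is estimated at 0.4 mL/min, within the range 0.12 mL/min to 1.3 mL/min.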

Compound 3, intrinsic clearance in a liver preparation (reported as CLH), per the amount of preparation that the assay uses: 0.01 mL/min
Estimate against measurement, compound 3: 40-fold (1.60 log units) above; the measured number lies below the stated range.
By their numbers in this assay, from the lowest: compound 3; then compound 2; then compound 1.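

Cyano in place of chloro on this aromatic carbon moves the number in this assay down much further than the exchange of one halogen for another did (a 21-fold lower number from compound 2 to compound 3 (1.32 log units; beyond the scatter)), and the same group in place of fluoro gives the largest step of the three (a 120-fold lower number from compound 1 to compound 3 (2.09 log units; beyond the scatter)). This place on the shared core therefore allows a group that is not a halogen to go well past both halogens, and the three compounds fall in the order cyano, chloro, fluoro from the lowest number, with every step beyond the scatter. Nothing shown here accounts for the size of these steps.

Going by these compounds, it remains open whether other groups at this place, such as a carboxylic acid, an amide or a methoxy group, would give numbers as low as cyano does. On these data alone, whether cyano would give a step of this size elsewhere on the shared core is also open.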